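Two Cyclopropyl Stereoisomers and an Antiproliferative Read-Out

A few compounds are considered here, and "the series" means these few. Any claim that something is new, unique, unknown or untested is made for them only; others in the source may bear on it.

Antiproliferative data are available for two compounds in a functional assay on HBL-100 cells (Homo sapiens) for antiproliferative activity, read by luminescence and CellTiter-Glo, with a stated time of 48 h; on this read-out higher numbers stand for weaker inhibition and lower numbers for stronger inhibition. Compound 1 `C[C@H](Cc1ccccc1)[C@H]1CCCC(=O)O1` gives > 100000 nM, which is a limit of the assay and not a number. For the measured compounds named here, compound 2 `O=C1C=CC[C@H]([C@@H]2C[C@H]2c2ccccc2)O1` gives 43400 nM, and this is the only true number so far, so it has no measured neighbour to be ranked against. Compound 3 `O=C1C=CC[C@H]([C@H]2C[C@@H]2c2ccccc2)O1` has the same connectivity as compound 2 and departs from it only in configuration: the two compounds have the same atoms and bonds and differ only in configuration as drawn: 2 of 3 stereo elements differ; a stereocentre at a saturated ring carbon is drawn R in compound 2 and S in compound 3; a stereocentre at a saturated ring carbon is drawn R in compound 2 and S in compound 3. Going by the values given here, no measured pair shows what such an inversion does in this assay, so neither direction is favoured and no change beyond the usual scatter is expected. The expected shift, a 1.1-fold lower number from compound 2 to compound 3 (0.04 log units; within the scatter), is therefore small, although the uncertainty is wide. For compound 3 the estimated value is 40000 nM, with an expected range of 15000 nM to 100000 nM.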

Compound 3, half-maximal inhibitory concentration: 14400 nM
Beside the measured number, compound 3's estimate is 2.8-fold (0.44 log units) above it, and the stated range ends above it.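

In this assay, for the compounds shown here, the result gives the first measured step, a 3.0-fold lower number from compound 2 to compound 3 (0.48 log units; beyond the scatter), and it shows that a change of configuration alone can move the read-out beyond the usual scatter. Until now, no measured pair had shown what such an inversion does. The step can be assigned to the drawn configuration, and to nothing else in the structures, because of one fact: the fact that compounds 2 and 3 differ only in the configuration as drawn.

Both stereocentres at saturated ring carbons change together in this step, so the compounds shown leave open whether inverting one of them alone would have the same effect or whether both are needed. They also leave open whether the gap between the two configurations would persist with an amine or a longer chain on the shared core.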